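The source may report more compounds than this note shows. Statements on the series, on what has been measured and on what is new or still open speak of the compounds shown alone.

Compound 1 `Cc1ccc(C)c(-c2nc(CN3CCC(C(=O)NCCCN4C[C@H](C)C[C@H](C)C4)CC3)c(C)o2)c1`: 4070 nM
Compound 2 `Cc1oc(-c2ccccc2Cl)nc1CN1CCC(C(=O)NCCCN2C[C@H](C)C[C@H](C)C2)CC1`: 16500 nM
Compound 3 `Cc1ccccc1-c1nc(CN2CCC(C(=O)NCCCN3CCC(C)(C)CC3)CC2)c(C)o1`: 10200 nM

In an ADME assay on Huh7.5.1 cells (Homo sapiens) for cytotoxicity, read by ATP content, with a stated time of 48 h (a higher number here means that more compound is tolerated, a lower number that less compound is tolerated), compound 2 gives 16500 nM. That places it within the scatter of compound 3 and clearly above compound 1. The next compound, compound 4 `Cc1oc(-c2c(Cl)cccc2Cl)nc1CN1CCC(C(=O)NCCCN2C[C@H](C)C[C@H](C)C2)CC1`, differs from compound 2 by a single change, (chloro in place of hydrogen on an aromatic carbon), which turns 2-chlorophenyl into 2,6-dichlorophenyl.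

Among the compounds with values here, no measured step makes this exact change. Within the data shown here, only one step alters this aryl group: a 4.1-fold higher number from compound 1 to compound 2 (0.61 log units; beyond the scatter). It is a modest step, and it replaces 2,5-dimethylphenyl rather than adding a chloro group, so it offers only loose guidance. Still, it shows that the number can move with this group, and that compound 1, with its disubstituted phenyl, has the lower value. A small move towards a lower number therefore seems more likely than a rise, though no large step is expected. The expected step is a 1.5-fold lower number from compound 2 to compound 4 (0.18 log units; within the scatter). For compound 4 the estimated value is 11000 nM, with an expected range from 4500 nM to 25000 nM.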

Compound 4, half-maximal cytotoxic concentration: 13200 nM
Compound 4: the middle estimate sits 1.2-fold (0.08 log units) below what was measured, within the range that was stated.
By their numbers in this assay, from the lowest: compound 1; then compounds 3, 4 and 2 (each within the scatter of the next).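

In this assay, a second chloro group, which turns 2-chlorophenyl into 2,6-dichlorophenyl, stays within the scatter: a 1.3-fold lower number from compound 2 to compound 4 (0.10 log units; within the scatter). Within the data shown here, this aromatic carbon therefore takes a chloro group in place of hydrogen without a readable shift in the tolerated concentration, whereas the earlier compounds showed only a swap of the whole aryl group. The distance from the 2,5-dimethylphenyl compound also remains beyond the scatter, at a 3.2-fold higher number from compound 1 to compound 4 (0.51 log units; beyond the scatter), and nothing shown here explains either step.

The compounds shown leave open how a fluoro, methoxy or trifluoromethyl group would read on this same aromatic carbon, and how an unsubstituted phenyl would compare. They also leave open whether the chloro change would read the same alongside the amine of compound 3.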